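Amide replacement in a fluorinated series: notes on compound 4

The compounds below may be only part of what the source reports. "The series", "measured", "known", "first", "only" and "open" are said of these compounds alone.

compound 1, `O=C(Nc1nccs1)c1cccc(Nc2ncc(F)c(Nc3ccc(F)cc3)n2)c1`, in a functional assay on KB cells (Homo sapiens) for antiproliferative activity, read by sulforhodamine B assay, with a stated time of 3 days; a higher number here means a weaker inhibitor of growth, a lower number a stronger inhibitor of growth: > 10000 nM (a limit)
compound 2, `CN(C)c1ccc(C(=O)Nc2cccc(Nc3ncc(F)c(Nc4ccc(F)cc4)n3)c2)cc1`, in this assay: > 10000 nM (a limit)
compound 3, `O=C(Nc1cc(Cl)cc(Cl)c1)c1cccc(Nc2ncc(F)c(Nc3ccc(F)cc3)n2)c1`, in this assay: 20100 nM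

Compound 1 stands at the limit of this assay, so its value is not a number. Compound 2 stands at the same limit. Compound 3 gives a number, but the step that the limit leaves unreadable from compound 1 to compound 3 remains unreadable due to the limit of > 10000 nM in this assay, at which 2 of the 3 values shown sit.

Compound 4, `CN(C)CC(=O)Nc1cccc(Nc2ncc(F)c(Nc3ccc(F)cc3)n2)c1`, differs from compound 1 by (((dimethylamino)methyl)carbonyl)amino in place of (1,3-thiazol-2-yl)carbamoyl on an aromatic carbon. Going by the values given here, no measured step speaks to this change: the single step in the set, the thiazolyl to dichlorophenyl swap, is itself unreadable, and every measured compound shows only weak growth inhibition in this assay. The step that the limit leaves unreadable from compound 1 to compound 4 is therefore expected to stay within scatter of the limit, in no clear direction. Compound 4 is estimated at 12000 nM, between 2500 nM and 40000 nM.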

Compound 4, concentration for 50% growth inhibition: 1260 nM
Beside the measured number, compound 4's estimate is 9.5-fold (0.98 log units) above it; the measured number lies below the stated range.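

In this assay, (((dimethylamino)methyl)carbonyl)amino on this aromatic carbon gives the first clear gain in the set, with an at least 7.9-fold lower number from compound 1 to compound 4 (0.89 log units; beyond the scatter) and a 16-fold lower number from compound 3 to compound 4 (1.20 log units; beyond the scatter). The dimethylamino group alone does not carry that gain, as compound 2 also holds one; (dimethylamino)methyl in place of 4-(dimethylamino)phenyl gives an at least 7.9-fold lower number from compound 2 to compound 4 (0.89 log units; beyond the scatter). Steps from compounds at the limit are bounds, not exact sizes: the limit of > 10000 nM in this assay, at which 2 of the 4 values shown sit.

The compounds shown leave open whether the gain follows the amine nitrogen or the ring-free chain. A morpholine or a longer chain carrying the dimethylamino group would test this.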